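This account rests on a few compounds, and the source may have more. Where it says the series, first, only, none or still open, it means among the compounds named here.

Compound 1 `COc1cc(/C=C2\CN(C)C/C(=C\c3ccccc3F)C2=O)cc(OC)c1OC` gives 4340 nM
Compound 2 `CN1C/C(=C\c2ccc(C(F)(F)F)cc2)C(=O)/C(=C/c2ccccc2F)C1` gives 6340 nM
Compound 3 `COc1cc(/C=C2\CN(C)C/C(=C\c3ccc(F)cc3)C2=O)cc(OC)c1` gives 11300 nM

Among the compounds with values here, these values come from a functional assay on K562 cells (Homo sapiens) for cytotoxicity, read by MTT assay, with a stated time of 24 h (on this read-out lower numbers stand for stronger inhibition and higher numbers for weaker inhibition), and no two of the compounds differ in one place only. Compound 3 stands within the scatter of compound 2 and beyond the scatter above compound 1. Compound 4 `COc1cc(/C=C2\CN(C)C/C(=C\c3ccc(Cl)c(Cl)c3)C2=O)cc(OC)c1` has not yet been measured. Within the data shown here, it differs from compound 3 by 3,4-dichlorophenyl in place of 4-fluorophenyl on a double-bonded chain carbon bound to a double-bonded ring carbon and no measured step isolates this change. A small move toward a lower number is expected in this assay with the estimated step of a 1.7-fold lower number from compound 3 to compound 4 (0.24 log units; within the scatter) staying within the scatter. For compound 4 the estimated value is 6500 nM (expected range 2500 nM to 14000 nM).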

Compound 4, half-maximal inhibitory concentration: 9490 nM
Compound 4: the middle estimate sits 1.5-fold (0.16 log units) below what was measured; low and high end bracket the measured number.
By their numbers in this assay, from the lowest: compounds 1, 2, 4 and 3 (each within the scatter of the next, the first and the last beyond it).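

In this assay, 3,4-dichlorophenyl in place of 4-fluorophenyl on a double-bonded chain carbon bound to a double-bonded ring carbon gives a step (a 1.2-fold lower number from compound 3 to compound 4 (0.08 log units; within the scatter)) that stays within the scatter. At this position, then, the two groups cannot be told apart on this read-out, despite the second chlorine-bearing ring carrying one more heavy atom. Nothing at hand bears on why the two read alike.

On these data alone, whether an amine or a carboxylic acid on this phenyl ring would move the number beyond the scatter remains open. So does whether this change would read the same alongside the other groups of compound 1 and compound 2.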